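The source may report more compounds than this note shows. Statements on the series, on what has been measured and on what is new or still open speak of the compounds shown alone.

In an in vitro ADME assay on microsomes (Rattus norvegicus) for metabolic stability (on this read-out higher numbers stand for fast clearance and lower numbers for slow clearance), compound 3 `O=C(CN(CC1CCC1)C(=O)c1ccc(-c2ccccn2)cc1)Nc1cc(F)cc(F)c1` gives 4.8 mL.min-1.g-1, within the scatter of compound 1 `O=C(CN(CC1CC1)C(=O)c1ccc(-c2ccccn2)cc1)Nc1cc(F)cc(F)c1` at 5 mL.min-1.g-1, whereas compound 2 `O=C(CN(C(=O)c1ccc(-c2ccccn2)cc1)C1CCOCC1)Nc1cc(F)cc(F)c1` gives 0.6 mL.min-1.g-1. Compound 4 `CCC(COC)N(CC(=O)Nc1cc(F)cc(F)c1)C(=O)c1ccc(-c2ccccn2)cc1` carries 1-(methoxymethyl)propyl in place of cyclobutylmethyl on an amide-type nitrogen. For the measured compounds named here, the nearest precedent is the modest 8.0-fold higher number from compound 2 to compound 3 (0.90 log units; beyond the scatter), and an 8.3-fold lower number from compound 1 to compound 2 (0.92 log units; beyond the scatter) is of similar size. Both involve oxan-4-yl, whereas a 1.0-fold lower number from compound 1 to compound 3 (0.02 log units; within the scatter) stays within the scatter. The entering group shares oxygen with oxan-4-yl but has no ring, and only part of that step is expected in this assay, towards a lower number. The expected step is a 2.2-fold lower number from compound 3 to compound 4 (0.34 log units; beyond the scatter). Compound 4 is expected at 2.2 mL.min-1.g-1, with an estimated range of 0.8 mL.min-1.g-1 to 5.5 mL.min-1.g-1.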

Compound 4, intrinsic clearance in microsomes: 6.7 mL.min-1.g-1
For compound 4 the middle estimate is 3.0-fold (0.48 log units) below the measured one; the whole stated range lies below it.
By their numbers in this assay, from the lowest: compound 2; then compounds 3, 1 and 4 (each within the scatter of the next).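

In this assay 1-(methoxymethyl)propyl on the amide-type nitrogen sits with the carbon-only groups, with a 1.4-fold higher number from compound 3 to compound 4 (0.14 log units; within the scatter) and a 1.3-fold higher number from compound 1 to compound 4 (0.13 log units; within the scatter) and not with oxan-4-yl, as shown by an 11-fold higher number from compound 2 to compound 4 (1.05 log units; beyond the scatter) as a large step. An oxygen in the group at this position is therefore not enough to give the low number seen for compound 2, which stands apart from the other three. Nothing at hand explains this difference.

Open, on these data alone, is whether the ring of oxan-4-yl, its oxygen, or both together set compound 2 apart. Cyclohexyl on the same nitrogen would separate ring from oxygen, and oxan-3-yl would test where the oxygen sits.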